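The compounds below may be only part of what the source reports. "The series", "measured", "known", "first", "only" and "open" are said of these compounds alone.

Compound 1 `CCc1cc(Cc2cccc(OC)c2)c(=O)n(CC(=O)Nc2ccc(I)cc2)n1` is a compound for which, in a functional assay on HL-60 cells (Homo sapiens), read by calcium flux (a lower number here means that less compound is needed, a higher number that more compound is needed for the effect), compound 1 gives only a limit, > 50000 nM.
Compound 2 `COc1cccc(Cc2cc(-c3ccccc3)nn(CC(=O)Nc3ccc(Br)cc3)c2=O)c1` is a compound for which, in this assay, compound 2 gives only a limit, > 50000 nM.
Compound 3 `COc1cccc(Cc2cc(-c3ccccc3)nn(CC(=O)Nc3ccc(F)cc3)c2=O)c1` is a compound for which, in this assay, compound 3 gives only a limit, > 50000 nM.

Among the compounds with values here, compound 3 therefore stands nowhere that can be ranked: its value in this assay is a limit, and every compound measured so far sits at the same point, as the limit of > 50000 nM in this assay, at which 3 of the 3 values shown sit, records. Within the data shown here, the one single-point step among the measured compounds, a step that the two limits leave unreadable from compound 2 to compound 3, exchanges fluoro for bromo on an aromatic carbon and is left unreadable by the two limits.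

Compound 4 `COc1ccc(-c2cc(Cc3cccc(OC)c3)c(=O)n(CC(=O)Nc3ccc(F)cc3)n2)cc1` differs from compound 3 in one place: methoxy in place of hydrogen on an aromatic carbon. The group sits on an aromatic carbon of a six-membered aromatic ring of carbon only, para to a large group; cut one bond further out, the change reads phenyl to 4-methoxyphenyl. Among the measured compounds shown here, no measured step touches this position, and the only step that exists could not be sized, so nothing in this assay points toward a shift in either direction.

Compound 4 is accordingly expected to remain at the limit, with a step of a number no higher from compound 3 to compound 4 (the limit leaves the size open) that is estimated as none beyond the scatter. The estimate for compound 4 in this assay is 50000 nM, spanning 15000 nM to 200000 nM, most likely reported again only as a limit.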

Compound 4, half-maximal effective concentration: > 50000 nM
Compound 4: a limit, no number; the forecaster's own chance of this, stated with the estimate: 85%; the middle value lies on the limit itself.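

Within the data shown here, compound 4 gives only a limit in this assay, > 50000 nM, as compound 3 does, so no step between compound 3 and compound 4 can be read, and the methoxy exchange has no measurable size. What the compounds shown leave open is how any change to them would act, since all rest at one point: the limit of > 50000 nM in this assay, at which 4 of the 4 values shown sit.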